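The compounds below may be only part of what the source reports. "The series", "measured", "known", "first", "only" and "open" are said of these compounds alone.

All values in an ADME assay on MT4 cells (Homo sapiens) for cytotoxicity, read by MTT assay (a lower number here means that less compound is tolerated, a higher number that more compound is tolerated), are limits and not numbers:

- Compound 1 `Cc1c(Cc2c(F)cccc2F)nc(SCc2ccccn2)[nH]c1=O` gives > 70000 nM as a limit
- Compound 2 `Cc1c(Cc2c(Cl)cccc2Cl)nc(SCC(=O)c2ccc(F)cc2)[nH]c1=O` gives > 57000 nM as a limit
- Compound 3 `COc1ccc(C(=O)CSc2nc(Cc3c(Cl)cccc3Cl)c(C)c(=O)[nH]2)cc1` gives > 56000 nM as a limit

Compound 3 stands at the limit of > 56000 nM in this assay, at which 1 of the 3 values shown sits, and has no readable number. The other two compounds also stand at limits, so the series offers no measured value to rank against.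

Compound 4 `CCc1c(Cc2c(Cl)cccc2Cl)nc(SCC(=O)c2ccc(OC)cc2)[nH]c1=O` differs from compound 3 by methyl in place of hydrogen on a saturated chain carbon bound to an aromatic carbon, which is methyl in place of hydrogen on a saturated chain carbon bound to an aromatic carbon, or methyl to ethyl when cut one bond further out.

For the measured compounds named here, only one measured step exists, a step that the two limits leave unreadable from compound 2 to compound 3, and it is methoxy in place of fluoro on an aromatic carbon. It is a different change and gives no size to carry over. In this assay no step beyond the scatter is expected, and no direction can be drawn from the data. Another report as a limit is the likeliest outcome. The expected step is an at least 1.1-fold lower number from compound 3 to compound 4 (0.04 log units; that floor lies within the scatter) as an estimate only.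

Compound 4 is expected at 50000 nM (estimated range 15000 nM to 100000 nM).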

Compound 4, half-maximal cytotoxic concentration: > 54000 nM
Compound 4 was reported as a limit; the forecaster's own chance of this, stated with the estimate: 70%; at least 1.0-fold (0.03 log units) between middle value and limit.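

In this assay compound 4 gives > 54000 nM, a limit and not a number. Compound 3 gives > 56000 nM, also a limit. No step can be read from compound 3 to compound 4. The compounds shown leave open the concentration at which any of them becomes cytotoxic.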